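Catechol variant of the thiazolethione series

The source may report more compounds than this note shows. Statements on the series, on what has been measured and on what is new or still open speak of the compounds shown alone.

The shared core of compound 2 `COc1cc(-n2c(-c3ccc(Cl)cc3)csc2=S)cc(OC)c1OC` carries a 4-chlorophenyl group. In a functional assay on MCF7 cells (Homo sapiens) for cytotoxicity, read by MTT assay, with a stated time of 48 h (on this read-out higher numbers stand for weaker inhibition and lower numbers for stronger inhibition), compound 2 gives > 100 ug/mL, which is a limit of the assay and not a number; this is the limit of > 100 ug/mL in this assay, at which 1 of the 3 values shown sits. Within the data shown here, compound 3 `COc1cc(-n2c(-c3ccc(-c4ccccc4)cc3)csc2=S)cc(OC)c1OC` gives 45.3 ug/mL, and the step of an at least 2.2-fold lower number from compound 2 to compound 3 (0.34 log units; beyond the scatter) is the only measured change at this position. Compound 1 `COc1cc(N2C(=S)SCC2(O)c2ccc(Cl)cc2Cl)cc(OC)c1OC`, built on a different core, gives 9.6 ug/mL. Compound 4 `COc1cc(-n2c(-c3ccc(O)c(O)c3)csc2=S)cc(OC)c1OC` differs from compound 2 by 3,4-dihydroxyphenyl in place of 4-chlorophenyl on an aromatic carbon. No measured step introduces hydroxyl groups here; the one step shown, chloro to phenyl, was at least modest and downward, so a change of similar or smaller size in either direction is expected, with a fair chance that compound 4 also returns only a limit. Compound 4 is estimated at 70 ug/mL (range 25 ug/mL to 200 ug/mL), which means an expected step of an at least 1.4-fold lower number from compound 2 to compound 4 (0.15 log units; that floor lies within the scatter).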

Compound 4, half-maximal inhibitory concentration: > 100 ug/mL
Compound 4: no number, only a limit (the forecaster's own chance of this, stated with the estimate: 45%); middle value at least 1.4-fold (0.15 log units) from the limit.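

Among these compounds, compound 2 and compound 4 each return only a limit and not a number, so no step between them can be read: the limit of > 100 ug/mL in this assay, at which 2 of the 4 values shown sit. As far as these compounds go, how 3,4-dihydroxyphenyl and 4-chlorophenyl compare on the shared core stays open.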